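A larger alkyne alcohol in place of methoxy

A few compounds are considered here, and "the series" means these few. Any claim that something is new, unique, unknown or untested is made for them only; others in the source may bear on it.

Measured compounds:
compound 1, `COc1cc(C(O)(C(F)(F)F)C(F)(F)F)cnc1N1CCN(S(=O)(=O)c2ccc(N)nc2)CC1`, < 14 mL.min-1.g-1
compound 2, `Nc1ccc(S(=O)(=O)N2CCN(c3ncc(C(O)(C(F)(F)F)C(F)(F)F)cc3C#CCO)CC2)cn1`, 65 mL.min-1.g-1

Compound 1 in an ADME assay (liver) for metabolic stability, with Liver microsome (Rattus norvegicus) as the target, using microsomes and NADPH, with a stated time of 30 min, tested at 1 uM (a higher number here means faster removal of the compound, a lower number slower removal), gives < 14 mL.min-1.g-1, and this is a limit of the assay rather than a number. Among the compounds with values here, it is the one value that sits at the limit of < 14 mL.min-1.g-1 in this assay, at which 1 of the 2 values shown sits. Compound 2 carries 3-hydroxyprop-1-yn-1-yl in place of methoxy on an aromatic carbon, and in this assay compound 2 gives 65 mL.min-1.g-1. The step is an at least 4.6-fold higher number from compound 1 to compound 2 (0.66 log units; beyond the scatter).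

The unmeasured compound 3 is `CC(C)(O)C#Cc1cc(C(O)(C(F)(F)F)C(F)(F)F)cnc1N1CCN(S(=O)(=O)c2ccc(N)nc2)CC1`. It differs from compound 1 by 3-hydroxy-3-methylbut-1-yn-1-yl in place of methoxy on an aromatic carbon. Within the data shown here, the one measured step that bears on this change is the one from compound 1 to compound 2, where an alkyne alcohol also replaced methoxy at the same place, and it was at least modest and upward. The account therefore expects a step of similar kind for compound 3, an at least 3.2-fold higher number from compound 1 to compound 3 (0.50 log units; beyond the scatter), in the direction of faster removal. Compound 3 is estimated at 45 mL.min-1.g-1, with a range from 15 mL.min-1.g-1 to 130 mL.min-1.g-1.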

Compound 3, intrinsic clearance in microsomes: 16 mL.min-1.g-1
Estimate against measurement, compound 3: 2.8-fold (0.45 log units) above; measured number inside the range.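

Replacing hydroxymethyl with 1-hydroxy-1-methylethyl on the triple-bonded carbon in this assay gives a 4.1-fold lower number from compound 2 to compound 3 (0.61 log units; beyond the scatter), so a high number does not come with every alkyne alcohol at this place, and the end of the chain matters as much as the triple bond. Set against methoxy, 3-hydroxy-3-methylbut-1-yn-1-yl gives an at least 1.1-fold higher number from compound 1 to compound 3 (0.05 log units; that floor lies within the scatter), so this larger alkyne alcohol is not shown to raise the number at all, although the smaller one did. The size of that step cannot be fixed any closer because compound 1 stands at a limit of the assay and not at a number: the limit of < 14 mL.min-1.g-1 in this assay, at which 1 of the 3 values shown sits.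

Within the data shown here, only two groups stand on the triple-bonded carbon here, so it remains open whether the number follows the hydroxyl carbon's substitution more widely, and where a methyl ether, an amine or a longer chain at that carbon would fall. Going by these compounds, it is also open how an alkyne with no hydroxyl at all would compare at this place, with compound 3 or with the methoxy of the core.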